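The source may report more compounds than this note shows. Statements on the series, on what has been measured and on what is new or still open speak of the compounds shown alone.

Compound 1 `O=C(NCCO)c1cccc2c1CCN2c1cc(Cc2cc(F)cc(C(F)(F)F)c2)ncn1`: 136%
Compound 2 `O=C(NCCO)c1cccc2c1CCN2c1cc(Cc2ccccc2C(F)(F)F)ncn1`: 115%

In a functional assay on HEK293 cells for agonist activity at G-protein coupled receptor 52 (Homo sapiens), read by cAMP accumulation, with a stated time of 15 min (on this read-out lower numbers stand for smaller maximal responses and higher numbers for larger maximal responses), compound 1 gives 136%, while compound 2 gives 115%. Among the measured compounds shown here, compound 2 thus stands lowest of the two numbers measured so far, with compound 1 as its only neighbour. For the measured compounds named here, the single measured step, a number 21 percentage points lower from compound 1 to compound 2 (beyond the scatter), came with an exchange of the aryl group on a saturated chain carbon bound to an aromatic carbon, and it was modest in size though beyond the scatter.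

Compound 3 `O=C(NCCO)c1cccc2c1CCN2c1cc(Cc2ccc(C(F)(F)F)cc2)ncn1` has not yet been measured. It differs from compound 2 as follows: 4-(trifluoromethyl)phenyl in place of 2-(trifluoromethyl)phenyl on a saturated chain carbon bound to an aromatic carbon. The two have the same atoms, joined differently. The step from compound 1 to compound 2 is the only one that bears on this change, since it too moved the substituents around the same ring at the same place; its modest size suggests a step of comparable magnitude here, with direction uncertain. Compound 3 is therefore expected to land between the two measured numbers, with a step of a number 10 percentage points higher from compound 2 to compound 3 (within the scatter) estimated. For compound 3 the estimate is 125%, with a range from 100% to 150%.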

Compound 3, largest response reached (Emax), in percent of the reference or control that the assay uses: 136%
The estimate for compound 3 lay 11 percentage points below the measured number; the measured number falls inside the stated range.
By their numbers in this assay, from the lowest: compound 2; then compounds 1 and 3 (each within the scatter of the next).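

In this assay, 4-(trifluoromethyl)phenyl in place of 2-(trifluoromethyl)phenyl on a saturated chain carbon bound to an aromatic carbon gives a number 21 percentage points higher from compound 2 to compound 3 (beyond the scatter), so with the same atoms joined differently, the arrangement of this group alone changes the maximal response beyond the scatter. Exchanging 3-fluoro-5-(trifluoromethyl)phenyl for 4-(trifluoromethyl)phenyl at the same place gives no change at the digits printed from compound 1 to compound 3 (within the scatter), which leaves compound 2 as the only one of the three set apart from the other two. Nothing in hand gives a reason for this difference among the three aryl groups.

The compounds shown leave open whether the response at this place depends on the trifluoromethyl group at all, or would be kept with an unsubstituted phenyl, a methoxy group or a nitrile on the ring in its stead. It also remains open whether the same differences among these aryl groups would hold if the chain on the amide of the shared core ended in an amine or a carboxylic acid rather than its hydroxyl group.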